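The compounds below may be only part of what the source reports. "The series", "measured", "known", "first", "only" and "open" are said of these compounds alone.

In an ADME assay (Mus musculus, strain C57BL/6) for metabolic stability, read by HPLC, with a stated time of 12 h (on this read-out higher numbers stand for a longer-lived compound and lower numbers for a shorter-lived compound), the measured compounds stand as follows:

Compound 1 `O=C(O)[C@@H](CO)NC(=O)[C@H]1C[C@@H](O)CN1`: > 12 h
Compound 2 `O=C(O)[C@H](CO)NC(=O)[C@@H]1C[C@H](O)CN1`: 1.15 h

Compound 1 has the value > 12 h, which is a limit of the assay and not a number. Among the compounds with values here, compound 2, at 1.15 h, therefore holds the only actual number and lies at the short-lived end of the pair. Compound 3 `O=C(N[C@H](CO)C(=O)O)[C@@H]1C[C@@H](O)CN1` differs from compound 2 in this way: the two compounds have the same atoms and bonds and differ only in configuration as drawn: 2 of 3 stereo elements differ; a stereocentre at a saturated chain carbon is drawn S in compound 2 and R in compound 3; a stereocentre at a saturated ring carbon is drawn S in compound 2 and R in compound 3. A stereocentre at a saturated chain carbon and one at a saturated ring carbon are both drawn S in compound 2 and R in compound 3. Within the data shown here, the one measured step that bears on this is an at least 10-fold lower number from compound 1 to compound 2 (1.01 log units; beyond the scatter). Going by these compounds, that large drop can be traced to configuration alone because of the fact that compounds 1 and 2 differ only in the configuration as drawn, while its full size stays open because of the limit of > 12 h in this assay, at which 1 of the 2 values shown sits. The step inverted all the stereocentres, so it does not show what each contributes. Compound 3 reverses two of those inversions, so a clear rise in this assay is expected, though probably only part of that large step. The expected move is a 4.3-fold higher number from compound 2 to compound 3 (0.64 log units; beyond the scatter). For compound 3 the estimate is 5 h, with an expected range of 1.5 h to 12 h.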

Compound 3, half-life: 0.99 h
Compound 3: the middle estimate sits 5.1-fold (0.70 log units) above what was measured; the measured number lies below the stated range.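

In this assay, inverting one stereocentre at a saturated ring carbon is enough on its own for a large fall: an at least 12-fold lower number from compound 1 to compound 3 (1.08 log units; beyond the scatter). This fall can be traced to that single ring carbon, with the other two stereocentres as drawn in compound 1: the fact that compounds 1 and 3 differ only in the configuration as drawn The remaining two stereocentres, the saturated chain carbon and the other saturated ring carbon, differ together in the next step, and that step stays within the scatter: a 1.2-fold lower number from compound 2 to compound 3 (0.07 log units; within the scatter), so the large step seen earlier need not be spread over all three stereocentres and can be carried by one ring carbon.

Compound 1 gives > 12 h, which is a limit of the assay and not a number. Going by these compounds, the full size of the fall therefore stays open, as does what the chain stereocentre or the other ring stereocentre would do if inverted singly in compound 1, where the two were seen only together and only in the short-lived configuration, and how the shared core would read in this assay with a methyl ester in place of the carboxylic acid.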